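Shifting a Methyl Group: From Compound 3 to Compound 4

The source may hold more compounds than are shown below. What is called first, only, known or untested is meant among the compounds shown, and "the series" means these compounds.

Compound 1 `Cc1cccc(N(C)CC2CCC/C(=C\c3ccccc3)C2=O)c1` gives 46.8% in a functional assay on the whole organism (strain Wistar) for inhibition, with Rattus norvegicus as the target, read by paw edema, with stated times of 1 h and 3 h, at a dose of 200 mg/kg by the oral route; on this read-out lower numbers stand for less inhibition and higher numbers for more inhibition at the one dose given (going by the name of the read-out).
Compound 2 `Cc1ccc(/C=C2\CCCC(CN(C)c3ccccc3)C2=O)cc1` gives 44.7% in this assay.
Compound 3 `Cc1ccc(/C=C2\CCCC(CN(C)c3ccc(C)cc3)C2=O)cc1` gives 38.3% in this assay.

Compound 3 has the lowest of the three readings, but its gaps to compound 2 and to compound 1 are both within the usual scatter, so the three compounds cannot be told apart on these numbers. Compound 4 `Cc1ccc(/C=C2\CCCC(CN(C)c3cccc(C)c3)C2=O)cc1` has not yet been measured. It differs from compound 3 by 3-methylphenyl in place of 4-methylphenyl on an amine nitrogen; the methyl group stays on the same ring but sits at a different carbon.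

Going by the values given here, only one measured step bears on this change. Placing a methyl on an aromatic carbon gave a number 6.4 percentage points lower from compound 2 to compound 3 (within the scatter), a change within the scatter. Among the compounds with values here, compound 1, which also carries a 3-methylphenyl on the amine nitrogen, shows a value close to compound 2, though the two differ elsewhere as well, so no step is drawn between them. Since adding the methyl changed little, moving it is expected to change little too, and for compound 4 a step of a number 3.7 percentage points higher from compound 3 to compound 4 (within the scatter) is expected, within the scatter. Compound 4 is therefore estimated at 42%, with a range from 32% to 52%.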

Compound 4, a percentage reported as inhibition, in the whole organism at one dose (the size of the read-out at that dose, not a potency): 36.2%
Beside the measured number, compound 4's estimate is 5.8 percentage points above it; the range from low to high includes it.
By their numbers in this assay, from the lowest: compounds 4, 3, 2 and 1 (each within the scatter of the next, the first and the last beyond it).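

Moving the methyl around the ring on the amine nitrogen, from 4-methylphenyl to 3-methylphenyl, gives a number 2.1 percentage points lower from compound 3 to compound 4 (within the scatter), so this assay does not tell these two placements apart. Going by these compounds alone, the new compound also gives two further methyl additions to read: a number 8.5 percentage points lower from compound 2 to compound 4 (within the scatter), and a number 10.6 percentage points lower from compound 1 to compound 4 (beyond the scatter), the first step in this small set to pass beyond the scatter, though only modestly. Adding a methyl to an aromatic carbon can now be compared across two pairs, and the two readings agree: the same change on two cores in this assay, a number 6.4 percentage points lower (within the scatter) from compound 2 to compound 3 and a number 10.6 percentage points lower (beyond the scatter) from compound 1 to compound 4, 4.2 percentage points apart, within the scatter of two such steps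

The compounds shown carry only methyl on their aromatic rings, so the effect of a methoxy group, a chlorine atom or a carboxylic acid on the phenyl attached to the amine nitrogen remains open. Each reading also comes from a single dose, so these numbers give the size of the inhibition at that dose and leave the potency of the compounds undefined.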